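This account rests on a few compounds, and the source may have more. Where it says the series, first, only, none or still open, it means among the compounds named here.

Measured so far:
Compound 1 `Cc1cccc(NNC(=O)c2ccc(NS(=O)(=O)c3cnc(O)nc3O)cc2)c1`: in a functional assay on OVCAR-3 cells (Homo sapiens) for antiproliferative activity, read by MTT assay, with a stated time of 24 h (a higher number here means a weaker inhibitor, a lower number a stronger inhibitor), compound 1 gives only a limit, > 20000 nM.
Compound 2 `O=C(NNc1ccccc1Cl)c1ccc(NS(=O)(=O)c2cnc(O)nc2O)cc1`: in this assay compound 2 gives 7230 nM.
Compound 3 `Cc1cccc(NNC(=O)c2ccccc2NS(=O)(=O)c2cnc(O)nc2O)c1`: in this assay compound 3 gives only a limit, > 20000 nM.

Two of the three values sit at the limit of > 20000 nM in this assay, at which 2 of the 3 values shown sit, so little can be ranked within the series. Going by the values given here, the single measured step is 2-chlorophenyl in place of 3-methylphenyl on an amine nitrogen, which gives an at least 2.7-fold lower number from compound 1 to compound 2 (0.44 log units; beyond the scatter). Compound 1 and compound 3 are built from the same atoms joined differently; the difference between the two cores is not broken down here.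

Compound 4 `O=C(NNc1ccccc1Cl)c1ccccc1NS(=O)(=O)c1cnc(O)nc1O` is not yet measured. It differs from compound 3 by 2-chlorophenyl in place of 3-methylphenyl on an amine nitrogen, the same change at the same place as that from compound 1 to compound 2. Among the compounds with values here, since compound 3 gives only a limit, the starting point is itself uncertain, and the expectation rests on the one measured pair alone. In this assay the expected step is an at least 2.0-fold lower number from compound 3 to compound 4 (0.30 log units; that floor lies within the scatter), set beside an at least 2.7-fold lower number from compound 1 to compound 2 (0.44 log units; beyond the scatter). Compound 4 is estimated at 10000 nM, between 3000 nM and 30000 nM, with a real chance that only a limit is returned.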

Compound 4, half-maximal inhibitory concentration: 14100 nM
Beside the measured number, compound 4's estimate is 1.4-fold (0.15 log units) below it; measured number inside the range.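

In this assay, 2-chlorophenyl in place of 3-methylphenyl on an amine nitrogen gives an at least 1.4-fold lower number from compound 3 to compound 4 (0.15 log units; that floor lies within the scatter) on the second core. Compound 3 gives only a limit (> 20000 nM), so this step is a floor and not a size. The floor on the second core stays within the scatter, so the two pairs suggest that the change carries over but do not establish it, and whether the size is shared stays unsettled: the same change on two cores in this assay, an at least 2.7-fold lower number (0.44 log units; beyond the scatter) from compound 1 to compound 2 and an at least 1.4-fold lower number (0.15 log units; that floor lies within the scatter) from compound 3 to compound 4; the limit leaves it open whether they differ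

The compounds shown leave open whether the step belongs to the chlorine itself or to the exchange of one whole aryl group for the other; 2-methylphenyl and 3-chlorophenyl would separate these two readings, and 2-methoxyphenyl would test whether a further group follows the same course. Any finer ranking of the series remains restricted by the upper end of the measured range: the limit of > 20000 nM in this assay, at which 2 of the 4 values shown sit.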